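Benzoyloxy in place of formyloxy on the ring carbon

The compounds below may be only part of what the source reports. "The series", "measured", "known", "first", "only" and "open" are said of these compounds alone.

Compound 1 `CO[C@H]1C(=O)N2C(C(=O)c3ccccc3)=C(CSc3nnnn3C)CS(=O)(=O)C12`: in a physicochemical assay, at pH 7.4 (a lower number here means that the compound disappears faster, a higher number that the compound lasts longer), compound 1 gives 17 h.
Compound 2 `CO[C@H]1C(=O)N2C(C(=O)C(C)(C)C)=C(C)[C@@H](Sc3nnc(C)s3)S(=O)(=O)C12`: in this assay compound 2 gives 27 h.
Compound 3 `CO[C@H]1C(=O)N2C(C(=O)C(C)(C)C)=C(C)[C@@H](OC=O)S(=O)(=O)C12`: in this assay compound 3 gives < 0.5 h, which is a limit of the assay and not a number.

Going by the values given here, compound 3 is the one member for which this assay yields only a limit; its value sits at the limit of < 0.5 h in this assay, at which 1 of the 3 values shown sits. Compound 2 and compound 3 share the core and differ at a single place: an at least 54-fold lower number from compound 2 to compound 3 (1.73 log units; beyond the scatter). Among the compounds with values here, this is the only measured step that touches the position in question. Within the data shown here, compound 1 differs from both in more than one place and gives no single step.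

Compound 4 `CO[C@H]1C(=O)N2C(C(=O)C(C)(C)C)=C(C)[C@@H](OC(=O)c3ccccc3)S(=O)(=O)C12` is the next member. Relative to compound 3 the change is phenyl in place of hydrogen on a carbonyl carbon. The ester on the ring carbon stays; only the acyl part grows. The measured step into compound 3 was large and went towards faster disappearance, but it exchanged the whole group on the ring carbon, whereas the move to compound 4 keeps the ester. Among the measured compounds shown here, no measured pair shows what a larger acyl group does here. A moderate gain in half-life over compound 3 is expected for compound 4, an at least 4.0-fold higher number from compound 3 to compound 4 (0.60 log units; beyond the scatter), though a number below compound 2 remains likelier given the step of an at least 54-fold lower number from compound 2 to compound 3 (1.73 log units; beyond the scatter). For compound 4 the estimate in this assay is 2 h, with a range from 0.4 h to 10 h.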

Compound 4, half-life: 24 h
For compound 4 the middle estimate is 12-fold (1.08 log units) below the measured one; measured number outside the range, above it.
By their numbers in this assay, from the lowest: compounds 1, 4 and 2 (each within the scatter of the next). At a limit, below all of these: compound 3.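

An ester on the ring carbon is not by itself tied to fast disappearance in this assay: with the ester kept, benzoyloxy in place of formyloxy gives an at least 48-fold higher number from compound 3 to compound 4 (1.68 log units; beyond the scatter). Benzoyloxy and (5-methyl-1,3,4-thiadiazol-2-yl)sulfanyl on this carbon cannot be told apart, with a 1.1-fold lower number from compound 2 to compound 4 (0.05 log units; within the scatter), so among the three groups shown on this carbon only formyloxy stands apart. The entry for compound 3 is a limit and not a number, and the step from it gives a bound only: the limit of < 0.5 h in this assay, at which 1 of the 4 values shown sits.

The compounds shown leave open whether the gain in half-life needs the phenyl ring of benzoyl or would also appear with acetyl or a longer alkyl chain on the carbonyl carbon, and whether a benzoyl group carrying an amine or a carboxylic acid would keep it. From the compounds shown here alone, how half-life runs across acyl groups between formyl and benzoyl also remains unknown, and compound 1 differs from the others in more than one place and cannot settle this.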